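Swapping an aromatic ring for tert-butyl on a thiourea

The compounds below may be only part of what the source reports. "The series", "measured", "known", "first", "only" and "open" are said of these compounds alone.

Compound 1 `Cc1ccccc1NC(=S)NC(=O)c1ccccc1`: 3540 nM
Compound 2 `CC(=O)NC(=S)Nc1ccncc1`: 2070 nM
Compound 3 `O=C(NC(=S)Nc1ccncc1)c1ccccc1`: 2280 nM

These three compounds were measured in an assay for inhibition of epoxide hydrolase 1 (Homo sapiens), read by fluorescence, using microsomes; a lower number here means a stronger inhibitor, a higher number a weaker inhibitor. Compound 3 gives the second highest of the three numbers; its nearest neighbour is compound 2, and the gap to it, as well as the larger gap to compound 1, stays within the scatter, so no order among the three can be read from the data.

Within the data shown here, the only single-point step among the measured compounds is a 1.1-fold higher number from compound 2 to compound 3 (0.04 log units; within the scatter), which changes the group on the carbonyl carbon. It says nothing about the group on the thiourea nitrogen.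

Compound 4 `CC(C)(C)NC(=S)NC(=O)c1ccccc1` differs from compound 3 by tert-butyl in place of pyridin-4-yl on an amide-type nitrogen. Among the measured compounds shown here, no measured step touches this position, so there is nothing to anchor a direction. The expectation for compound 4 is therefore a number close to that of compound 3, with a wide range: 2500 nM (range 800 nM to 8000 nM), which means an expected step of a 1.1-fold higher number from compound 3 to compound 4 (0.04 log units; within the scatter) in this assay.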

Compound 4, half-maximal inhibitory concentration: 1580 nM
Compound 4: middle estimate off by 1.6-fold (0.20 log units), on the high side; the measured number falls inside the stated range.
By their numbers in this assay, from the lowest: compounds 4, 2, 3 and 1 (each within the scatter of the next, the first and the last beyond it).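

Among these compounds, the first change at this position, a 1.4-fold lower number from compound 3 to compound 4 (0.16 log units; within the scatter), replaces pyridin-4-yl with tert-butyl on the amide-type nitrogen. The aromatic ring and its hydrogen-bond acceptor both leave, along with two heavy atoms, yet the number in this assay does not move beyond the scatter, so for this pair a ring on this nitrogen is not needed for a value in this range. Nothing among the data gives a reason for this.

Only one swap at this nitrogen is shown, so it remains open whether a cyclohexyl group, a longer chain such as octyl or a chain ending in a carboxylic acid would move the number beyond the scatter. On these data alone, it is also open whether tert-butyl would give the same result with methyl on the carbonyl carbon, as in compound 2.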